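Working notes: 4-methoxyphenyl in place of 3-nitrophenyl

The source may hold more compounds than are shown below. What is called first, only, known or untested is meant among the compounds shown, and "the series" means these compounds.

Measured in a functional assay on U-251 cells (Homo sapiens) for inhibition, read by MTT assay, with a stated time of 2 days; a lower number here means a stronger inhibitor of growth, a higher number a weaker inhibitor of growth:
- compound 1 `Nc1ccccc1NC(=O)CCCNCC(=O)Nc1cccc([N+](=O)[O-])c1`: 93500 nM
- compound 2 `Nc1ccccc1NC(=O)c1ccc(NCC(=O)Nc2cccc([N+](=O)[O-])c2)cc1`: 52000 nM
- compound 3 `Nc1ccccc1NC(=O)CCCNCC(=O)Nc1cc(Cl)ccc1Cl`: > 100000 nM (a limit of the assay, not a number)

Compound 2 at 52000 nM lies within the usual scatter of compound 1 at 93500 nM, so no order holds between these two. Going by the values given here, the only other reading is the limit of compound 3.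

Compound 4 `COc1ccc(NC(=O)CNc2ccc(C(=O)Nc3ccccc3N)cc2)cc1` is next, with 4-methoxyphenyl in place of 3-nitrophenyl on an amide-type nitrogen of compound 2: 4-methoxyphenyl in place of 3-nitrophenyl on an amide-type nitrogen.

Among the compounds with values here, one measured step bears on this, with 2,5-dichlorophenyl replacing the same 3-nitrophenyl on the core of compound 1: an at least 1.0-fold higher number from compound 1 to compound 3 (0.02 log units; that floor lies within the scatter). It is only a floor and sets no size for the new change, and it comes from a different core. No step beyond the scatter is therefore expected in this assay, with a slight lean towards a higher number.

The estimated step is a 1.3-fold higher number from compound 2 to compound 4 (0.10 log units; within the scatter). For compound 4 the estimated value is 65000 nM, with an expected range of 28000 nM to 130000 nM.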

Compound 4, concentration for total growth inhibition: > 100000 nM
Compound 4 ended at the assay's limit (the forecaster's own chance of this, stated with the estimate: 30%); at least 1.5-fold (0.18 log units) between middle value and limit.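

On the core of compound 2, 4-methoxyphenyl in place of 3-nitrophenyl gives, in this assay, an at least 1.9-fold higher number from compound 2 to compound 4 (0.28 log units; that floor lies within the scatter), so no order between the two can be stated, and this position shows no measured gain from the change. Compound 4 gives > 100000 nM, which is a limit of the assay and not a number. Both replacements of 3-nitrophenyl, on two different cores, now end at that limit, so neither step has a size, only a floor: the limit of > 100000 nM in this assay, at which 2 of the 4 values shown sit.

On these data alone, whether 3-methoxyphenyl or 4-nitrophenyl on this amide-type nitrogen would give a number under the limit remains open, which leaves the roles of the nitro group and of its place on the ring unseparated. As far as these compounds go, how far compound 3 and compound 4 lie past the limit also remains open.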